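This account rests on a few compounds, and the source may have more. Where it says the series, first, only, none or still open, it means among the compounds named here.

Working notes on the series, read in a functional assay on MGC-803 cells (Homo sapiens) for inhibition, read by sulforhodamine B assay; a higher number here means a weaker inhibitor, a lower number a stronger inhibitor. Compound 1 `O=C1C=C(NCc2ccccc2)C(=O)c2c1nc1n2[C@H]2OC[C@@H](O)[C@H]2OC1` gives 2670 nM and compound 2 `O=C1C(Nc2ccccc2F)=CC(=O)c2c1nc1n2[C@H]2OC[C@@H](O)[C@H]2OC1` gives 2000 nM, two values within the scatter of each other. Compound 3 `O=C1C(NC2CCCC2)=CC(=O)c2c1nc1n2[C@H]2OC[C@@H](O)[C@H]2OC1` gives > 16000 nM, which is a limit of the assay and not a number. For the measured compounds named here, compound 1 thus stands level with compound 2, the only other compound with a true number.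

Compound 4 `CCc1ccc(NC2=CC(=O)c3nc4n(c3C2=O)[C@H]2OC[C@@H](O)[C@H]2OC4)cc1` is still unmeasured and differs from compound 1 by 4-ethylphenyl in place of benzyl on an amine nitrogen, with 4-ethylphenyl in place of benzyl on an amine nitrogen. Going by the values given here, the one measured step that bears on this is an at least 8.0-fold higher number from compound 2 to compound 3 (0.90 log units; beyond the scatter), with cyclopentyl in place of 2-fluorophenyl, and it is beyond the scatter. Compound 4 keeps a phenyl on that nitrogen, as compound 2 does at 2000 nM, so no loss of that size is expected. The expected change is a 1.1-fold lower number from compound 1 to compound 4 (0.03 log units; within the scatter), which lies within the scatter. For compound 4 the estimate is 2500 nM, with an expected range of 800 nM to 8000 nM.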

Compound 4, half-maximal inhibitory concentration: 1290 nM
Compound 4: the middle estimate sits 1.9-fold (0.29 log units) above what was measured, and the stated range covers the measured number.
By their numbers in this assay, from the lowest: compounds 4, 2 and 1 (each within the scatter of the next, the first and the last beyond it). At a limit, above all of these: compound 3.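

In this assay, the change from benzyl to 4-ethylphenyl on the amine nitrogen gives a 2.1-fold lower number from compound 1 to compound 4 (0.32 log units; beyond the scatter), the first step read on the substituent of compound 1 itself, since the earlier step concerned only compounds 2 and 3. It shows that an aryl group attached directly to this nitrogen is tolerated here and gives a modest gain over benzyl, in contrast to the loss seen when cyclopentyl replaces 2-fluorophenyl in that earlier step. Nothing in the data at hand gives a cause for this step.

The step combines two changes, removal of the benzyl carbon link and addition of the ethyl group, and separating them would take a plain phenyl on this nitrogen. As far as these compounds go, how a longer chain such as butyl, or a carboxylic acid, would read in place of the ethyl also stays open.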